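From nitro to hydroxy on compound 3

The source may hold more compounds than are shown below. What is called first, only, known or untested is meant among the compounds shown, and "the series" means these compounds.

Measured in a functional assay on HeLa cells (Homo sapiens) for inhibition, read by MTT assay, with a stated time of 72 h; a higher number here means a weaker inhibitor, a lower number a stronger inhibitor:
compound 1 `O=[N+]([O-])c1ccc(-c2nnc(SCCCN3CCN(c4nc5ccccc5o4)CC3)o2)cc1` gives 114000 nM
compound 2 `CC(C)(C)Oc1ccc(-c2nnc(SCCCN3CCN(c4nc5ccccc5o4)CC3)o2)cc1` gives 269000 nM
compound 3 `O=[N+]([O-])c1ccc(-c2nnc(SCCCN3CCN(c4nc5ccccc5s4)CC3)o2)cc1` gives 97800 nM

Compound 3 at 97800 nM lies within the scatter of compound 1 and well under compound 2. Compound 4 `Oc1ccc(-c2nnc(SCCCN3CCN(c4nc5ccccc5s4)CC3)o2)cc1` changes one group: hydroxy in place of nitro on an aromatic carbon. Among the measured compounds shown here, no hydroxy compound has been measured yet. The nearest guide is another replacement of nitro, tert-butoxy, which gives a 2.4-fold higher number from compound 1 to compound 2 (0.37 log units; beyond the scatter), a modest step. The other measured step, a 1.2-fold lower number from compound 1 to compound 3 (0.07 log units; within the scatter), lies elsewhere in the molecule and within the scatter. One example is thin evidence, so a similar modest rise in this assay is expected, and the step expected is a 1.7-fold higher number from compound 3 to compound 4 (0.24 log units; within the scatter). Compound 4 is estimated at 170000 nM, with an expected range of 75000 nM to 380000 nM.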

Compound 4, half-maximal inhibitory concentration: 139000 nM
Beside the measured number, compound 4's estimate is 1.2-fold (0.09 log units) above it, and the stated range covers the measured number.
By their numbers in this assay, from the lowest: compounds 3, 1, 4 and 2 (each within the scatter of the next, the first and the last beyond it).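

In this assay, replacing nitro with hydroxy at this position of the 4-nitrophenyl group gives a 1.4-fold higher number from compound 3 to compound 4 (0.15 log units; within the scatter), so this pair shows no real change even though a smaller group with a hydrogen-bond donor enters. The earlier replacement at this position, tert-butoxy on compound 1, went beyond the scatter, so not every replacement of nitro behaves alike across the compounds shown. Nothing measured here explains this difference. An amine or a carboxylic acid at this position remains untested in the compounds shown. As far as these compounds go, how hydroxy behaves with the 1,3-benzoxazol-2-yl group of compound 1 also remains open.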